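Carbamoyl to Methoxycarbonyl: Compound 1 and Compound 3

The source may report more compounds than this note shows. Statements on the series, on what has been measured and on what is new or still open speak of the compounds shown alone.

In a functional assay on MCF7 cells (Homo sapiens) for inhibition, read by sulforhodamine B assay, with a stated time of 72 h (on this read-out lower numbers stand for stronger inhibition of growth and higher numbers for weaker inhibition of growth), compound 1 `NC(=O)/C=C/c1ccncc1-c1ccc2ccccc2c1` gives only a limit, > 10000 nM. Compound 2 `Cn1ccc2cc(-c3cnccc3/C=C/C(=O)O)ccc21` also reaches no number in this assay, giving > 10000 nM. Both values sit at the limit of > 10000 nM in this assay, at which 2 of the 2 values shown sit, so compound 1 stands at the same limit as the other measured compound. Compound 3 `COC(=O)/C=C/c1ccncc1-c1ccc2ccccc2c1` differs from compound 1 by methoxy in place of amino on a carbonyl carbon. Among the compounds with values here, no two measured compounds differ in one place, so no measured step sets the size of this change, and no shift beyond the scatter is expected in this assay. Compound 3 is therefore estimated at 20000 nM, between 5000 nM and 100000 nM. The expected step that the limit leaves unreadable from compound 1 to compound 3 is none beyond the scatter.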

Compound 3, concentration for 50% growth inhibition: 8170 nM
Compound 3: the middle estimate sits 2.4-fold (0.39 log units) above what was measured; the measured number falls inside the stated range.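

In this assay, compound 3 is the first compound shown to give a number rather than a limit, leaving two values at that limit: the limit of > 10000 nM in this assay, at which 2 of the 3 values shown sit. Methoxy in place of amino on the carbonyl carbon gives an at least 1.2-fold lower number from compound 1 to compound 3 (0.08 log units; that floor lies within the scatter). The reading for compound 1 is a limit, so this step is only a floor and its full size stays unread.

Open, on these data alone, is how a carboxylic acid or an ethyl ester on the core of compound 1 would read. Also open, as far as these compounds go, is how a methylamide would compare at this carbonyl carbon.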